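The source may hold more compounds than are shown below. What is called first, only, known or untested is meant among the compounds shown, and "the series" means these compounds.

The study compares three measured compounds and one still to be measured. Compound 1 `Cn1c(NN)nc(-c2cccc(O)c2O)c(C#N)c1=O` gives the lowest number of the three in a functional assay, with a stated time of 150 min (on this read-out lower numbers stand for stronger inhibition and higher numbers for weaker inhibition), namely 44 ug/mL. Compound 2 `CSc1nc(-c2cccs2)c(C#N)c(=O)n1C` gives 87 ug/mL in this assay, a number that lies within the usual scatter of the value for compound 1, so no order between the two can be claimed. Compound 3 `CCOC(=O)c1cnn(-c2nc(-c3ccccc3Cl)c(C#N)c(=O)n2C)c1N` gives 93 ug/mL in this assay, which does lie beyond the scatter from compound 1, though only just.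

Compound 4 `CSc1nc(-c2cccc(O)c2O)c(C#N)c(=O)n1C` is the one not yet measured. Relative to compound 1 it differs in one place: methylsulfanyl in place of aminoamino on an aromatic carbon. For the measured compounds named here, no pair of measured compounds differs by this change alone, so the size of its effect is not known from the data. Compound 2 carries the same methylsulfanyl group and gives 87 ug/mL, a somewhat higher number than compound 1; on that basis a modest rise in the number is expected for compound 4, with the step of a 1.6-fold higher number from compound 1 to compound 4 (0.20 log units; within the scatter) estimated to stay close to the scatter. Compound 4 is therefore expected to give about 70 ug/mL in this assay, with a likely range from 30 ug/mL to 160 ug/mL.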

Compound 4, half-maximal inhibitory concentration: 53 ug/mL
For compound 4 the middle estimate is 1.3-fold (0.12 log units) above the measured one; measured number inside the range.
By their numbers in this assay, from the lowest: compounds 1, 4, 2 and 3 (each within the scatter of the next, the first and the last beyond it).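

In this assay, for the compounds shown here, putting methylsulfanyl in place of aminoamino gives a 1.2-fold higher number from compound 1 to compound 4 (0.08 log units; within the scatter), the first direct reading of this change at this position. On this aromatic carbon, between two ring nitrogen atoms and para to a cyano group, the two groups therefore cannot be put in order, even though methylsulfanyl carries none of the hydrogen-bond donors of aminoamino. No measured property of either group is available to explain this result.

As far as these compounds go, it remains open how other groups on this carbon would read, such as a simple amine, a methoxy group or a longer alkylsulfanyl chain. From the compounds shown here alone, it is also open whether the same exchange would read alike if the core of compound 1 carried a different aromatic group in place of its hydroxylated one.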